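Benzyl substituent and tolerated concentration in MT4 cells

This account rests on a few compounds, and the source may have more. Where it says the series, first, only, none or still open, it means among the compounds named here.

compound 1 `Cc1cccc(Cn2cc(CNC(=O)c3cnc(Nc4ccc(C#N)cc4)cc3Oc3c(C)cc(C)cc3C)nn2)c1`: 114000 nM
compound 2 `Cc1cc(C)c(Oc2cc(Nc3ccc(C#N)cc3)ncc2C(=O)NCc2cn(Cc3ccccc3C#N)nn2)c(C)c1`: > 219000 nM, a limit
compound 3 `Cc1cc(C)c(Oc2cc(Nc3ccc(C#N)cc3)ncc2C(=O)NCc2cn(Cc3ccc(Cl)cc3)nn2)c(C)c1`: >= 120000 nM, a limit

In an ADME assay on MT4 cells (Homo sapiens) for cytotoxicity, read by MTT assay, with a stated time of 5 days (a higher number here means that more compound is tolerated, a lower number that less compound is tolerated), compound 1 gives 114000 nM. For compound 2 the value > 219000 nM is a limit of the assay. For compound 3 the value >= 120000 nM is also a limit; compound 3 sits at the limit of >= 120000 nM in this assay, at which 1 of the 3 values shown sits, with only a floor known. Compound 4 `Cc1cc(C)c(Oc2cc(Nc3ccc(C#N)cc3)ncc2C(=O)NCc2cn(Cc3ccc([N+](=O)[O-])cc3)nn2)c(C)c1` differs from compound 3 by nitro in place of chloro on an aromatic carbon. For the measured compounds named here, no measured step alters this position in the same way; the available steps are an at least 1.0-fold higher number from compound 1 to compound 3 (0.02 log units; that floor lies within the scatter), an at least 1.9-fold higher number from compound 1 to compound 2 (0.28 log units; that floor lies within the scatter) and a step that the two limits leave unreadable from compound 2 to compound 3. All three measured compounds tolerate high concentrations; a step beyond the scatter is not expected. Compound 4 is expected at 130000 nM, between 60000 nM and 260000 nM. The expected step that the limit leaves unreadable from compound 3 to compound 4 lies within the scatter.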

Compound 4, half-maximal cytotoxic concentration: >= 139000 nM
Compound 4 ended at the assay's limit; the forecaster's own chance of this, stated with the estimate: 60%; middle value at least 1.0-fold (0.02 log units) from the limit.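

In this assay, compound 4 yields only a limit, so 4-nitrobenzyl, like 4-chlorobenzyl, gives a floor and no measured value: the limit of >= 139000 nM in this assay, at which 1 of the 4 values shown sits. For the compounds shown here, the one readable step is an at least 1.2-fold higher number from compound 1 to compound 4 (0.08 log units; that floor lies within the scatter). As far as these compounds go, the steps linking compound 4 to the other two limits cannot be read, so nitro in place of chloro shows no sign of lowering the tolerated concentration, but its size remains unknown.

From the compounds shown here alone, the actual values of compound 2, compound 3 and compound 4 remain open. So does whether an amine or a carboxylic acid on this aromatic ring would lower the tolerated concentration.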